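The compounds below may be only part of what the source reports. "The series", "measured", "known", "first", "only" and "open" are said of these compounds alone.

Working notes on the series. For the measured compounds named here, compound 3 `Cc1cc(C(=O)O)nn1Cc1cc(Br)ccc1OCc1ccccc1Cl` gives 28.8 nM in a functional assay on CHO-K1 cells for antagonist activity at prostaglandin E2 receptor EP1 subtype (Homo sapiens), read by FLIPR (a lower number here means a stronger inhibitor, a higher number a weaker inhibitor), the highest of the three numbers so far: its nearest neighbour is compound 2 `Cc1cc(C(=O)O)nn1Cc1cc(Br)ccc1OCc1ccc(F)cc1F` with 2.63 nM, and the furthest is compound 1 `Cc1cc(C(=O)O)nn1Cc1cc(Br)ccc1OCc1ccc(Cl)cc1Cl` with 0.49 nM. The steps that separate them are an 11-fold higher number from compound 2 to compound 3 (1.04 log units; beyond the scatter) and a 59-fold higher number from compound 1 to compound 3 (1.77 log units; beyond the scatter), and between the other two, a 5.4-fold higher number from compound 1 to compound 2 (0.73 log units; beyond the scatter).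

Compound 4 `Cc1cc(C(=O)O)nn1Cc1cc(Br)ccc1OCc1cccc(Cl)c1` has the same atoms as compound 3, joined differently: 3-chlorophenyl in place of 2-chlorophenyl on a saturated chain carbon bound to an oxygen on an aromatic ring. Going by the values given here, no measured step in the set does this; every step so far adds, removes or swaps halogens on that ring rather than rearranging one chlorine. The step of a 59-fold higher number from compound 1 to compound 3 (1.77 log units; beyond the scatter) shows that the ring is sensitive to what it carries, and an 11-fold higher number from compound 2 to compound 3 (1.04 log units; beyond the scatter) points the same way, but neither says whether a 3-chlorophenyl behaves like a 2-chlorophenyl or not. With no guide in either direction, compound 4 is expected to stay near compound 3, and the step of a 1.2-fold lower number from compound 3 to compound 4 (0.06 log units; within the scatter) is therefore estimated as none beyond the scatter, though with wide uncertainty. For compound 4 the estimate in this assay is 25 nM, within a range from 6 nM to 110 nM.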

Compound 4, inhibition constant: 427 nM
Compound 4: the middle estimate sits 17-fold (1.23 log units) below what was measured; measured number outside the range, above it.
By their numbers in this assay, from the lowest: compound 1; then compound 2; then compound 3; then compound 4.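

Moving one chlorine, with the atoms otherwise unchanged, is enough to shift the result in this assay: 3-chlorophenyl in place of 2-chlorophenyl gives a 15-fold higher number from compound 3 to compound 4 (1.17 log units; beyond the scatter) on the saturated chain carbon bound to an oxygen on an aromatic ring. The earlier steps shown here added, removed or swapped halogens, so they showed that this ring is sensitive to what it carries; this step shows that where the single chlorine stands matters as well, by a margin beyond the scatter. The gap to the dihalogenated members is wider still, at a 160-fold higher number from compound 2 to compound 4 (2.21 log units; beyond the scatter) and an 870-fold higher number from compound 1 to compound 4 (2.94 log units; beyond the scatter), which makes compound 4 the weakest inhibitor of the four, with its steps to all the others printed as beyond the scatter.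

Still open, going by these compounds, is how a 4-chlorophenyl would compare with the 2-chlorophenyl and 3-chlorophenyl of this series, and whether a methoxy or trifluoromethyl group in the place of the chlorine would follow the same order. Nothing at hand accounts for the size of this step.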